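This account rests on a few compounds, and the source may have more. Where it says the series, first, only, none or still open, it means among the compounds named here.

Compound 1 `O=[N+]([O-])c1c(CS(=O)(=O)c2ccccc2)nc2c(C#Cc3cccc(F)c3)cc(Cl)cn12` gives only a limit in an ADME assay on HepG2 cells (Homo sapiens) for cytotoxicity, read by MTT assay, with a stated time of 72 h (on this read-out lower numbers stand for higher toxicity in this test and higher numbers for lower toxicity in this test), > 3900 nM. Among the compounds with values here, compound 2 `O=[N+]([O-])c1c(CS(=O)(=O)c2ccccc2)nc2c(C#CCOc3ccccc3)cc(Cl)cn12` gives 8400 nM, the only actual number in this assay. Compound 3 `CCC(O)CC#Cc1cc(Cl)cn2c([N+](=O)[O-])c(CS(=O)(=O)c3ccccc3)nc12` differs from it by 1-hydroxypropyl in place of phenoxy on a saturated chain carbon bound to a triple-bonded carbon, with 1-hydroxypropyl in place of phenoxy on a saturated chain carbon bound to a triple-bonded carbon. Within the data shown here, the sole measured step, a step that the limit leaves unreadable from compound 1 to compound 2, offers no size to carry over because of the limit of > 3900 nM in this assay, at which 1 of the 2 values shown sits. The expected change in this assay is therefore none beyond the scatter, with a 1.2-fold higher number from compound 2 to compound 3 (0.08 log units; within the scatter) as the estimated step. For compound 3 the expected value is 10000 nM, with an estimated range of 3500 nM to 30000 nM.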

Compound 3, half-maximal cytotoxic concentration: > 62500 nM
Compound 3: only a limit was reported; the forecaster's own chance of this, stated with the estimate: 35%; middle value at least 6.2-fold (0.79 log units) away from the limit.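

In this assay, within the data shown here, 1-hydroxypropyl in place of phenoxy on a saturated chain carbon bound to a triple-bonded carbon gives an at least 7.4-fold higher number from compound 2 to compound 3 (0.87 log units; beyond the scatter), the first step at this position with a readable size, towards lower toxicity in this test. From the compounds shown here alone, compound 3 gives only a limit, > 62500 nM, so the full size of that step stays unknown. The step from compound 1 to compound 3 cannot be read.

Going by these compounds, whether the departure of phenoxy or the arrival of the hydroxyl carries the step stays open, since both change at once. A plain butyl chain or an amine at this place would help separate the two.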